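One added methyl on an inactive compound

This account rests on a few compounds, and the source may have more. Where it says the series, first, only, none or still open, it means among the compounds named here.

In a functional assay on HCT-116 cells (Homo sapiens) for antiproliferative activity, read by MTT assay, with a stated time of 72 h (a lower number here means a stronger inhibitor, a higher number a weaker inhibitor), compound 2 `CO[C@@H]1C[C@@H]2O[C@@]2(C)C(=O)N[C@@H](C(C)C)C(=O)N[C@H](Cc2cc(Cl)c(O)c(Cl)c2)C(=O)N[C@@H](C(C)(C)O)C(=O)O[C@H](c2ccccc2)[C@H](C)/C=C/C=C/1C` is reported as "not active" (no number reported), with no number given. Its relative compound 1 `CC[C@H](C)[C@@H]1NC(=O)[C@]2(C)O[C@H]2C[C@@H](OC)/C(C)=C/C=C/[C@@H](C)[C@@H](c2ccccc2)OC(=O)[C@H](C(C)(C)O)NC(=O)[C@@H](Cc2cc(Cl)c(O)c(Cl)c2)NC1=O` gives > 1000 nM, which is a limit and not a number. Compound 3 `CO[C@@H]1C[C@@H]2O[C@@]2(C)C(=O)N(C)[C@@H](C(C)C)C(=O)N[C@H](Cc2cc(Cl)c(O)c(Cl)c2)C(=O)N[C@@H](C(C)(C)O)C(=O)O[C@H](c2ccccc2)[C@H](C)/C=C/C=C/1C` has not yet been measured. The step methyl in place of hydrogen on an amide-type nitrogen in a ring puts methyl in place of hydrogen on an amide-type nitrogen in a ring. Within the data shown here, no measured pair shows what such a change does, so no shift beyond the usual scatter is expected in this assay, and weak activity remains the likely outcome. Compound 3 is estimated at 3000 nM, with an expected range of 800 nM to 20000 nM.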

Compound 3, half-maximal inhibitory concentration: 6.7 nM
Compound 3: the middle estimate sits 450-fold (2.65 log units) above what was measured; the whole stated range lies above it.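

No step can be read from compound 2 to compound 3: compound 2 is reported only as "not active", with no number. The compounds shown leave open how much activity the methyl on the amide-type nitrogen adds.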